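Bromo to Chlorofluorophenyl on a Nucleoside Core

The source may report more compounds than this note shows. Statements on the series, on what has been measured and on what is new or still open speak of the compounds shown alone.

compound 1, `Nc1ncnc2c([C@@H]3O[C@H](CO)[C@@H](O)[C@H]3O)cnn12`: > 64000 nM
compound 2, `Nc1ncnn2c([C@@H]3O[C@H](CO)[C@@H](O)[C@H]3O)cc(Br)c12`: 2000 nM
compound 3, `O=c1[nH]cnn2c([C@@H]3O[C@H](CO)C[C@H]3O)ccc12`: > 64000 nM

Of the compounds shown here, three have been tested in an ADME assay on cells (Macrophage, Mus musculus) for cytotoxicity; on this read-out higher numbers stand for lower toxicity in this test and lower numbers for higher toxicity in this test. Compound 1 reaches only a limit of the assay, > 64000 nM. Compound 3 likewise reaches only a limit, > 64000 nM. Among the compounds with values here, compound 2 is the only one with a real number, giving 2000 nM. Within the data shown here, the other two sit at the limit of > 64000 nM in this assay, at which 2 of the 3 values shown sit, so compound 2 stands alone as the one measurably toxic compound here. Compound 4, `Nc1ncnn2c([C@@H]3O[C@H](CO)[C@@H](O)[C@H]3O)cc(-c3ccc(Cl)c(F)c3)c12`, is not yet measured; it differs from compound 2 by 4-chloro-3-fluorophenyl in place of bromo on an aromatic carbon. Among the measured compounds shown here, no pair of measured compounds differs in just one place, so nothing yet shows how such a change moves this read-out. A step beyond the scatter toward higher toxicity is nevertheless expected, a 2.5-fold lower number from compound 2 to compound 4 (0.40 log units; beyond the scatter). Compound 4 is expected to give 800 nM, within 150 nM to 6000 nM.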

Compound 4, half-maximal cytotoxic concentration: > 64000 nM
Compound 4: no number, only a limit; the forecaster's own chance of this, stated with the estimate: 10%; middle value at least 80-fold (1.90 log units) away from the limit.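

Within the data shown here, on this aromatic carbon, 4-chloro-3-fluorophenyl in place of bromo gives an at least 32-fold higher number from compound 2 to compound 4 (1.50 log units; beyond the scatter) in this assay, the first single change here that can be read, and it runs toward lower toxicity in this test. Compound 4 gives > 64000 nM, which is a limit of the assay and not a number. Compound 4 thus joins the other compounds at that limit, leaving compound 2 alone with a real number: the limit of > 64000 nM in this assay, at which 3 of the 4 values shown sit.

The compounds shown leave open whether the phenyl ring or its two halogens account for this step. A plain phenyl, or a chloro or methyl on the same carbon, would help separate these.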